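Chloro on the aryl ring of an inactive sulfone

The source may hold more compounds than are shown below. What is called first, only, known or untested is meant among the compounds shown, and "the series" means these compounds.

Working notes on the series. Within the data shown here, compound 1 `COc1ccc(-c2nn(-c3ccccc3)c(-c3ccc(C)cc3)c2S(=O)(=O)CC2=NCCO2)cc1` is the only member with a numeric read-out: in a functional assay, read by Griess assay, with a stated time of 150 min, tested at 100 ug/mL (a higher number here means a stronger effect of the compound at the concentration tested, a lower number a weaker effect), compound 1 gives 68.2%. Compound 2 `O=S(=O)(CC1=NCCO1)C1=NNCC1c1ccccc1` carries a much smaller scaffold, and in this assay compound 2 is reported as "not active" (no number reported), with no number attached. Compound 3 `O=S(=O)(CC1=NCCS1)C1=NNCC1c1ccccc1` shares this outcome: in this assay compound 3 is reported as "not active" (no number reported), again without a number. Among the measured compounds shown here, compound 2 therefore stands without a single value, alongside one further entry of the same kind, and no step between it and any measured compound can be sized.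

The step under consideration leads to compound 4 `O=S(=O)(CC1=NCCO1)C1=NNCC1c1ccc(Cl)cc1`, which differs from compound 2 by chloro in place of hydrogen on an aromatic carbon. For the measured compounds named here, with compound 2 reported only as inactive and no measured step to lean on, any change in this assay is expected to be small, most likely none beyond the scatter, with a weak upward drift at most. For compound 4 the read-out in this assay is expected near 10%, within a range from 0% to 30%.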

Compound 4, a percentage reported as activity, at one concentration (the size of the read-out at that concentration, not a potency): "not active" (no number reported)
Nothing numeric was reported for compound 4; there is nothing to compare the estimate with.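

Compound 2 and compound 4 both stand without a number in this assay, so no step can be read from phenyl to 4-chlorophenyl, and nothing shown bears on this outcome. The compounds shown leave open whether this change alters the read-out where activity is measurable.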